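This account rests on a few compounds, and the source may have more. Where it says the series, first, only, none or still open, it means among the compounds named here.

Notes on the series. The shared core stands in compound 1 `COc1ccc(/C(=C(/CCN=[N+]=[N-])c2ccccc2)c2ccccc2)cc1`, which bears an azide on the side chain; in a functional assay on MCF7 cells (Homo sapiens) for cytotoxicity, read by MTT assay, with a stated time of 72 h (on this read-out lower numbers stand for stronger inhibition and higher numbers for weaker inhibition), compound 1 is recorded as "not active" (no number reported), with no number attached. Compound 2 `COc1ccc(/C(=C(/CCNC(=O)NCc2ccccc2)c2ccccc2)c2ccccc2)cc1` carries a benzylamino group on the urea carbonyl. In this assay compound 2 gives only the limit > 50000 nM, not a number. Compound 3 `COc1ccc(/C(=C(/CCNC(=O)N2CCOCC2)c2ccccc2)c2ccccc2)cc1` carries morpholin-4-yl on that carbonyl carbon instead. In this assay compound 3 likewise gives only the limit > 50000 nM, again not a number. Compound 3 therefore stands nowhere that can be placed on the numbers shown: its own entry is a limit, one further value is a limit, and the remaining entry carries no number at all. The step that the two limits leave unreadable from compound 2 to compound 3 cannot be sized, since the limit of > 50000 nM in this assay, at which 2 of the 3 values shown sit, sits at both of its ends.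

Compound 4 `COc1ccc(/C(=C(/CCNC(=O)C(=O)N2CCCCC2)c2ccccc2)c2ccccc2)cc1` is the next member. The change from compound 3: (piperidin-1-yl)carbonyl in place of morpholin-4-yl on a carbonyl carbon. For the measured compounds named here, the one measured step bears on it only in that both of its ends sat at the limit; it gives neither a direction nor a size. The expected step that the limit leaves unreadable from compound 3 to compound 4 is therefore none beyond the scatter, with a limit the most likely report once more. For compound 4 the estimated value in this assay is 60000 nM, within the range 20000 nM to 150000 nM.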

Compound 4, half-maximal inhibitory concentration: > 50000 nM
Compound 4 ended at the assay's limit; the forecaster's own chance of this, stated with the estimate: 75%; the middle value lies beyond the limit too.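

No new step can be read: compound 2, compound 3 and compound 4 all end at the same limit, so the steps among them cannot be sized: the limit of > 50000 nM in this assay, at which 3 of the 4 values shown sit.

The compounds shown leave open whether any change on the carbonyl carbon gives a measurable value in this assay, and how far compound 2, compound 3 and compound 4 lie apart.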